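This account rests on a few compounds, and the source may have more. Where it says the series, first, only, none or still open, it means among the compounds named here.

Compound 1 `COC(=O)C1=C(C)N(C)C(=O)NC1c1cccs1` and compound 2 `CCCOC(=O)C1=C(C)N(C)C(=O)NC1c1cccs1` share one core and differ only in the ester chain. In an assay on membranes from HeLa cells for displacement of a labelled ligand from adenosine receptor A3 (Homo sapiens), read by scintillation counting, with a stated time of 180 min, tested at 1 uM (on this read-out higher numbers stand for more inhibition at the one concentration tested (going by the name of the read-out) and lower numbers for less inhibition), compound 1 gives 15%, while compound 2 gives 4%. Among the measured compounds shown here, compound 2 stands lowest of the two numbers measured so far; the nearest is compound 1, and the gap is the step of a number 11 percentage points lower from compound 1 to compound 2 (beyond the scatter), a modest drop that lies beyond the scatter. Compound 3 `CC1=C(C(=O)OC(C)C)C(c2cccs2)NC(=O)N1C` has not yet been measured in this assay. It differs from compound 2 by isopropyl in place of propyl on an oxygen next to a carbonyl group, so the same three carbons are kept and only rearranged. For the measured compounds named here, the one step that bears on this position is the lengthening from compound 1 to compound 2, which lowered the read-out modestly; the change to compound 3 keeps the chain size and therefore the expected step of a number 3 percentage points higher from compound 2 to compound 3 (within the scatter) is small, likely within the scatter, with at most a slight rise toward the value of compound 1. For compound 3 the estimate in this assay is 7%, expected to fall between -5% and 19%.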

Compound 3, a percentage reported as inhibition, at one concentration (the size of the read-out at that concentration, not a potency): 17%
Estimate against measurement, compound 3: 10 percentage points below; the measured number falls inside the stated range.
By their numbers in this assay, from the lowest: compound 2; then compounds 1 and 3 (each within the scatter of the next).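

In this assay, the read-out at this position is not set by the carbon count of the chain alone: propyl and isopropyl keep the same atoms, joined differently, on the oxygen next to a carbonyl group, and the change gives a number 13 percentage points higher from compound 2 to compound 3 (beyond the scatter). Set against methyl, isopropyl gives a number 2 percentage points higher from compound 1 to compound 3 (within the scatter), so the two esters cannot be told apart here, and of the three chains only propyl, with a number 11 percentage points lower from compound 1 to compound 2 (beyond the scatter), stands apart from the others. Nothing at hand explains why the two chains with the same carbon count part in this way.

On these data alone, it remains open whether the higher number follows branching in general, which a tert-butyl or a cyclopropyl ester would test, or belongs to isopropyl alone, and whether a longer chain such as butyl would stay with compound 2 at 4% or with compound 3 at 17%. Also open, as far as these compounds go, is whether the ester oxygen matters at all, a question that an amide or a carboxylic acid at this place would address.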